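A few compounds are considered here, and "the series" means these few. Any claim that something is new, unique, unknown or untested is made for them only; others in the source may bear on it.

Measured compounds:

Compound 1, `O=C(CSc1nnnn1-c1ccccc1)N/N=c1/scc(-c2ccc(Br)cc2)n1-c1ccccc1`, gives 47.9% in a functional assay on C6 cells (Rattus norvegicus) for cytotoxicity, read by MTT assay, with a stated time of 24 h, tested at 25 ug/mL; a higher number here means a weaker effect of the compound at the concentration tested, a lower number a stronger effect.
Compound 2, `Cc1ccc(-c2cs/c(=N/NC(=O)CSc3nncn3C)n2-c2ccccc2)cc1`, gives 70.7% in this assay.
Compound 3, `Cc1ccc(-c2cs/c(=N/NC(=O)CSc3nnnn3C)n2-c2ccccc2)cc1`, gives 60.7% in this assay.

Of these three numbers, compound 1 stands lowest; its nearest neighbour is compound 3, whose value lies beyond the scatter above it, and compound 2 lies further still. For the measured compounds named here, the only step between measured compounds is a number 10 percentage points lower from compound 2 to compound 3 (within the scatter), which changes the ring on the sulfur and not the aryl group on the shared core.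

Compound 4, `O=C(CSc1nnnn1-c1ccccc1)N/N=c1/scc(-c2ccc(Cl)cc2)n1-c1ccccc1`, is not yet measured. It differs from compound 1 in one place: chloro in place of bromo on an aromatic carbon. Going by the values given here, no measured pair shows this exchange of halogens, and the step from compound 2 to compound 3 concerns a different part of the molecule, so nothing in the data points to a change beyond the scatter. The expectation for compound 4 is therefore a step of a number 4.1 percentage points higher from compound 1 to compound 4 (within the scatter), and its value in this assay is estimated at 52%, with a range from 38% to 68%.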

Compound 4, a percentage reported as activity, at one concentration (the size of the read-out at that concentration, not a potency): 62.3%
The estimate for compound 4 lay 10.3 percentage points below the measured number; the measured number falls inside the stated range.
By their numbers in this assay, from the lowest: compound 1; then compounds 3, 4 and 2 (each within the scatter of the next).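

In this assay, chloro in place of bromo gives a number 14.4 percentage points higher from compound 1 to compound 4 (beyond the scatter), so the effect of the compound at the concentration tested is weaker with chloro. For the compounds shown here, the earlier compounds offered only a change in the ring on the sulfur, and that step stayed within the scatter; this is the first measured exchange on the aromatic carbon para to a large group, and it shows that replacing one halogen with the other at this position is enough to move the read-out beyond the scatter. Nothing measured here accounts for this step.

As far as these compounds go, whether fluoro, a methoxy group, an amine or a carboxylic acid at this position would lower or raise the number remains open. So does whether the step from bromo to chloro would recur with a different group on the sulfur.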